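Amino swap on the shared core: compound 2 to compound 3

The source may hold more compounds than are shown below. What is called first, only, known or untested is meant among the compounds shown, and "the series" means these compounds.

In a functional assay on MCF7 cells (Homo sapiens) for inhibition, read by sulforhodamine B assay (on this read-out higher numbers stand for weaker inhibition and lower numbers for stronger inhibition), compound 2 `O=C1C(N2CCCC2)=CC(=O)c2c1nc1n2[C@H]2OC[C@@H](O)[C@H]2OC1` gives only a limit, > 16000 nM. Compound 1 `O=C1C(Nc2ccccc2F)=CC(=O)c2c1nc1n2[C@H]2OC[C@@H](O)[C@H]2OC1` also gives only a limit, > 4000 nM. No exact value is therefore available in this small set, and compound 2 has no number from which to measure a step.

Compound 3 `O=C1C(NC2CC2)=CC(=O)c2c1nc1n2[C@H]2OC[C@@H](O)[C@H]2OC1` keeps the shared core and carries cyclopropylamino in place of pyrrolidin-1-yl on a double-bonded ring carbon.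

Going by the values given here, only one measured step bears on this change, at the same place on the core: a step that the two limits leave unreadable from compound 1 to compound 2, with pyrrolidin-1-yl in place of (2-fluorophenyl)amino. Its size and direction cannot be read, so it gives only weak guidance. Cyclopropylamino is closer in kind to the (2-fluorophenyl)amino of compound 1, whose limit of the limit of > 4000 nM in this assay, at which 1 of the 2 values shown sits, leaves room for stronger inhibition than the limit of compound 2 does. A modest move toward stronger inhibition is therefore expected, with a real chance of no readable change. The estimated step is an at least 1.7-fold lower number from compound 2 to compound 3 (0.24 log units; that floor lies within the scatter). For compound 3 the expected value is 9000 nM, with an estimated range of 2500 nM to 30000 nM.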

Compound 3, half-maximal inhibitory concentration: > 16000 nM
Compound 3: a limit, no number; the forecaster's own chance of this, stated with the estimate: 60%; middle value at least 1.7-fold (0.24 log units) from the limit.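

Compound 3 gives only a limit in this assay, as do compound 1 and compound 2, so the steps among these three compounds cannot be read. The compounds shown leave open whether any of these amino groups on the shared core gives an exact value, and how the three compare in strength of inhibition.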